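Fluoro for hydroxy on compound 2

The compounds below may be only part of what the source reports. "The series", "measured", "known", "first", "only" and "open" are said of these compounds alone.

Only compound 1 (`COc1cc(-c2nncn2-c2ccc(N(C)C)cc2)cc(OC)c1OC`) and compound 2 (`COc1ccc(-n2cnnc2-c2cc(OC)c(OC)c(OC)c2)cc1O`) have been measured so far. In a functional assay on NCI-H522 cells (Homo sapiens) for inhibition (on this read-out higher numbers stand for weaker inhibition of growth and lower numbers for stronger inhibition of growth), compound 1 gives 57.5 nM and compound 2 gives 263 nM as the higher number of the pair, so compound 2 is the weaker growth inhibitor of the two. Compound 3 (`COc1ccc(-n2cnnc2-c2cc(OC)c(OC)c(OC)c2)cc1F`) is compound 2 with fluoro in place of hydroxy on an aromatic carbon. Among the measured compounds shown here, no measured pair shows this swap, so the expectation is cautious. In this assay the expected step is small and upward (a 1.3-fold higher number from compound 2 to compound 3 (0.10 log units; within the scatter)), likely within the scatter. Compound 3 is expected to read 330 nM (estimated range 90 nM to 1200 nM).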

Compound 3, concentration for 50% growth inhibition: 4570 nM
Compound 3: the middle estimate sits 14-fold (1.14 log units) below what was measured; measured number above the stated range.
By their numbers in this assay, from the lowest: compound 1; then compound 2; then compound 3.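

In this assay, replacing hydroxy with fluoro on this aromatic carbon gives a 17-fold higher number from compound 2 to compound 3 (1.24 log units; beyond the scatter) and so weakens growth inhibition well beyond the scatter. This position is therefore sensitive to the group it carries, even when one heavy atom simply replaces another. The swap also removes the hydroxy group's hydrogen-bond donor and acceptor, but nothing available here explains the loss.

On these data alone, it remains open whether a primary amine or a carboxylic acid on this carbon would read closer to compound 2 or to compound 3.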